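Adding a Methoxy Group: What Compound 4 Might Show

The compounds below may be only part of what the source reports. "The series", "measured", "known", "first", "only" and "open" are said of these compounds alone.

Three compounds have been measured in a functional assay on MDA-MB-231 cells (Homo sapiens) for inhibition, read by MTT assay, with a stated time of 48 h; on this read-out lower numbers stand for stronger inhibition and higher numbers for weaker inhibition:

Compound 1, `COc1cc(C2=NOC(c3c[nH]c4ccccc34)C2)cc(OC)c1OC`, gives 11700 nM.
Compound 2, `Clc1ccc(Cn2cc(C3CC(c4ccncc4)=NO3)c3ccccc32)cc1`, gives 13700 nM.
Compound 3, `COc1ccc2c(c1)c(C1CC(c3ccncc3)=NO1)cn2Cc1ccc(Cl)cc1`, gives 26000 nM.

Compound 1 has the lowest of the three numbers. Compound 2 lies within the scatter of it, so no order between them can be claimed; compound 3 lies beyond the scatter of compound 1. The difference between the cores of compound 1 and compound 2 is not broken down here.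

Between compound 2 and compound 3 one change is made, (methoxy in place of hydrogen on an aromatic carbon), and in this assay it gave a 1.9-fold higher number from compound 2 to compound 3 (0.28 log units; within the scatter), a step that stays within the scatter.

Compound 4, `COc1ccc2[nH]cc(C3CC(c4cc(OC)c(OC)c(OC)c4)=NO3)c2c1`, is not yet measured. Among the compounds with values here, it differs from compound 1 by methoxy in place of hydrogen on an aromatic carbon, which is the same change as the one from compound 2 to compound 3, made on a different core.

Within the data shown here, with only that one earlier step to go on, the expected step is a 1.7-fold higher number from compound 1 to compound 4 (0.23 log units; within the scatter), resting on compound 3 and its a 1.9-fold higher number from compound 2 to compound 3 (0.28 log units; within the scatter) relative to compound 2. Compound 4 is therefore estimated at 20000 nM, with a likely range from 8000 nM to 50000 nM.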

Compound 4, half-maximal inhibitory concentration: 26000 nM
Compound 4: middle estimate off by 1.3-fold (0.11 log units), on the low side; measured number inside the range.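

In this assay, methoxy in place of hydrogen on an aromatic carbon gave a 2.2-fold higher number from compound 1 to compound 4 (0.35 log units; beyond the scatter), a modest step in the direction of weaker inhibition. Set beside the earlier step on the other core, the size of the change carried over, with no difference that can be told apart: the same change on two cores in this assay, a 1.9-fold higher number (0.28 log units; within the scatter) from compound 2 to compound 3 and a 2.2-fold higher number (0.35 log units; beyond the scatter) from compound 1 to compound 4, 1.2-fold (0.07 log units) apart, within the scatter of two such steps. Within the data shown here, this shows only that the two pairs in hand are consistent, and it does not establish a general rule, since it rests on two cores and one pair on each, the earlier step alone does not stand clear of the scatter, and nothing here says why the numbers moved.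

What the compounds shown leave open is whether any other group on that aromatic carbon, such as a hydroxyl, a fluorine atom or an amine, would shift the number in the same direction or the opposite one. From the compounds shown here alone, it also remains open whether the same agreement between cores would hold for such a group, or for methoxy on a third core.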